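A few compounds are considered here, and "the series" means these few. Any claim that something is new, unique, unknown or untested is made for them only; others in the source may bear on it.

Compound 3 `COC(=O)CCCCC[C@H](NC(=O)OC(C)(C)C)C(=O)NC1CCCC1` gives 60% in an assay on isolated protein for inhibition of protein deacetylase HDAC6 (Homo sapiens), read by fluorescence, tested at 1 uM (a lower number here means less inhibition, a higher number more inhibition at the concentration tested (going by the name of the read-out)), the second highest of three numbers: compound 2 `COC(=O)CCCCC[C@H](NC(=O)OCc1ccccc1)C(=O)NC1CCCC1` gives 65%, and compound 1 `O=C(O)CCCC[C@H](NC(=O)OCc1ccccc1)C(=O)NC1CCCC1` gives 20%. Compound 4 `CC(C)(C)OC(=O)N[C@@H](CCCCCCO)C(=O)NC1CCCC1` differs from compound 3 by hydroxymethyl in place of methoxycarbonyl on a saturated chain carbon, six bonds along the chain from an amide-type nitrogen and a carbonyl carbon. Among the measured compounds shown here, only one measured step alters a group on the saturated chain: a number 45 percentage points higher from compound 1 to compound 2 (beyond the scatter). The other, a number 5 percentage points lower from compound 2 to compound 3 (within the scatter), alters the carbamate and says little here. Because compound 1, carrying a carboxy group on that chain, gives 20%, removing the ester is expected to lower inhibition, though a hydroxymethyl need not fall as far as the carboxy did. Compound 4 is therefore expected to give 35%, between 10% and 60%. That amounts to an expected step of a number 25 percentage points lower from compound 3 to compound 4 (beyond the scatter), beyond the scatter.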

Compound 4, a percentage reported as inhibition, at one concentration (the size of the read-out at that concentration, not a potency): 3%
Beside the measured number, compound 4's estimate is 32 percentage points above it; the whole stated range lies above it.
By their numbers in this assay, from the lowest: compound 4; then compound 1; then compounds 3 and 2 (each within the scatter of the next).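

In this assay, the end of this chain proves sensitive to change: with the tert-butyl carbamate held fixed, hydroxymethyl in place of methoxycarbonyl gives a number 57 percentage points lower from compound 3 to compound 4 (beyond the scatter). The loss seen earlier with a carboxy group is therefore not confined to that group, since it also appears here with a group carrying no net charge. No measurement on hand explains the drop. The compounds shown leave open whether an amine, a primary amide or a longer chain ending in the ester would keep inhibition at this position.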